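The source may hold more compounds than are shown below. What is called first, only, known or untested is meant among the compounds shown, and "the series" means these compounds.

Compound 1 `CC/C=C/C(=O)Nc1cc2c(N3CCc4ccccc43)ncnc2cc1OC` and compound 2 `COc1cc2ncnc(N3CCc4ccccc43)c2cc1NC(=O)/C=C/C(C)C` share a core and differ only in the side chain of the amide. In a functional assay on PC-3 cells (Homo sapiens) for antiproliferative activity, read by MTT assay, with a stated time of 72 h (a lower number here means a stronger inhibitor, a higher number a weaker inhibitor), compound 1 gives 5890 nM, and compound 2 gives 6530 nM; the change between them, (methyl in place of hydrogen on a saturated chain carbon bound to a double-bonded chain carbon and a saturated chain carbon), produced a 1.1-fold higher number from compound 1 to compound 2 (0.04 log units; within the scatter). Compound 3 `CC/C=C/C(=O)Nc1cc2c(N3CCCc4ccccc43)ncnc2cc1O[C@@H]1CCOC1` carries a different core; the difference between the two cores is not broken down here. In this assay compound 3 gives 14300 nM. Compound 4 `CC(C)/C=C/C(=O)Nc1cc2c(N3CCCc4ccccc43)ncnc2cc1O[C@@H]1CCOC1` is derived from compound 3 by the same change, (methyl in place of hydrogen on a saturated chain carbon bound to a double-bonded chain carbon and a saturated chain carbon). Since the step from compound 1 to compound 2 stayed within the scatter, the step from compound 3 to compound 4 is expected to be about as small, namely a 1.1-fold higher number from compound 3 to compound 4 (0.03 log units; within the scatter). Compound 4 is therefore estimated at 15500 nM in this assay, between 7500 nM and 32000 nM.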

Compound 4, half-maximal inhibitory concentration: 8510 nM
Compound 4: the middle estimate sits 1.8-fold (0.26 log units) above what was measured; the range from low to high includes it.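

In this assay, methyl in place of hydrogen on the saturated chain carbon gives a 1.7-fold lower number from compound 3 to compound 4 (0.23 log units; within the scatter) and so stays within the scatter on this core as well. Set beside the earlier step, the two do not differ by more than two such steps normally would: the same change on two cores in this assay, a 1.1-fold higher number (0.04 log units; within the scatter) from compound 1 to compound 2 and a 1.7-fold lower number (0.23 log units; within the scatter) from compound 3 to compound 4, 1.9-fold (0.27 log units) apart, within the scatter of two such steps

For the compounds shown here, this shows that ethyl to isopropyl carried from one core to the other without a detectable difference, but with only two pairs it does not show that the change would carry to further cores, nor that it has any effect of its own.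

The compounds shown leave open what an amine on the amide side chain would give on either core. They also leave open what a longer chain or a cyclopropyl group in place of the isopropyl would give.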